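Methoxy additions across a shared core: cytotoxicity notes

The source may report more compounds than this note shows. Statements on the series, on what has been measured and on what is new or still open speak of the compounds shown alone.

The series comprises compound 1 `COc1ccc(-c2cc(/C=C/C(=O)c3ccc(N)cc3)[nH]n2)cc1`, compound 2 `COc1ccc(C(=O)/C=C/c2cc(-c3cc(OC)c(OC)c(OC)c3)n[nH]2)cc1OC`, compound 3 `COc1ccc(-c2cc(/C=C/C(=O)c3ccc(N)cc3)[nH]n2)cc1OC` and the not yet measured compound 4 `COc1cc(C(=O)/C=C/c2cc(-c3cc(OC)c(OC)c(OC)c3)n[nH]2)cc(OC)c1OC`. In a functional assay on SNB-19 cells (Homo sapiens) for cytotoxicity, read by sulforhodamine B assay, with a stated time of 48 h, tested at 100 uM (a higher number here means a weaker effect of the compound at the concentration tested, a lower number a stronger effect), compound 1 gives -80%, compound 3 gives -91% and compound 2 gives -95%.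

Compound 1 and compound 3 differ by methoxy in place of hydrogen on an aromatic carbon. That change makes the step of a number 11 percentage points lower from compound 1 to compound 3 (beyond the scatter). The difference between the cores of compound 1 and compound 2 is not broken down here. Compound 2 and compound 3 sit within the scatter of each other in this assay, so no order between them is claimed.

Compound 4 differs from compound 2 by methoxy in place of hydrogen on an aromatic carbon. The surroundings of the place are not identical to those in the earlier pair: in compound 4 the entering methoxy is ortho to a methoxy group, meta to a large group and also meta to a methoxy group, whereas in compound 3 it is ortho to a methoxy group and meta to a large group only. It is therefore the same kind of change, not the same change.

The earlier step of a number 11 percentage points lower from compound 1 to compound 3 (beyond the scatter) rests on a single pair. The step from compound 2 to compound 4 is expected to be smaller, a number 2 percentage points lower from compound 2 to compound 4 (within the scatter), because compound 2 already gives -95% and little room remains in this read-out. Compound 4 is estimated at -97% in this assay, expected to fall between -100% and -88%.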

Compound 4, a percentage reported as activity, at one concentration (the size of the read-out at that concentration, not a potency): -98%
For compound 4 the middle estimate is 1 percentage points above the measured one; the measured number falls inside the stated range.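

Read in this assay, methoxy in place of hydrogen on an aromatic carbon gives a number 3 percentage points lower from compound 2 to compound 4 (within the scatter). Set beside the earlier pair, the size of the step does not separate the two cores: the same change on two cores in this assay, a number 11 percentage points lower (beyond the scatter) from compound 1 to compound 3 and a number 3 percentage points lower (within the scatter) from compound 2 to compound 4, 8 percentage points apart, within the scatter of two such steps. For the compounds shown here, this shows that the two steps run the same way in number and that no dependence on the core can be read from them, but it does not show that the change carries equally from one core to another, since only two pairs are available, one of the two steps stays within the scatter, and the entering methoxy in compound 4 is also meta to a methoxy group, which makes it the same kind of change and not the same change.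

The compounds shown leave open whether another group in the same place, such as a hydroxyl, an ethoxy or a chlorine atom, would give a step like these on either core. They also leave open how the compounds would compare at lower concentrations, as each value here is a read-out at one concentration and not a potency.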